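The source may report more compounds than this note shows. Statements on the series, on what has been measured and on what is new or still open speak of the compounds shown alone.

Measured compounds:
Compound 1, `COc1ccc(-c2cc(-c3cccc(S(C)(=O)=O)c3)cnc2N)cn1`, gives 3.78 h in an in vitro ADME assay on microsomes from liver (Homo sapiens) for metabolic stability; a lower number here means that the compound disappears faster, a higher number that the compound lasts longer.
Compound 2, `COc1ccc(-c2cc(-c3ccc(S(=O)(=O)NC4CC4)cc3)cnc2N)cn1`, gives 1.9 h in this assay.
Compound 3, `COc1ccc(-c2cnc(N)c(-c3ccc(OC)nc3)c2)cn1`, gives 1.45 h in this assay.

Of these three numbers, compound 2 holds the second highest. Its nearest neighbour is compound 3, whose number is lower by an amount that sits within the usual scatter of the measurement, and the furthest is compound 1, whose number is higher by an amount that also stays within that scatter. So far, then, the three measured compounds cannot be told apart with confidence on this read-out.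

Compound 4 has the structure `CNC(=O)c1ccc(-c2cnc(N)c(-c3ccc(OC)nc3)c2)cc1`. It differs from compound 2 in one place: methylcarbamoyl in place of cyclopropylsulfamoyl on an aromatic carbon. Among the measured compounds shown here, no step between two measured compounds mirrors this change, so there is nothing in the measured set that shows how such a swap moves the half-life. With no such comparison at hand, the expectation is for no step beyond the scatter, in either direction. The expected step from compound 2 to compound 4 is therefore a 1.1-fold lower number from compound 2 to compound 4 (0.02 log units; within the scatter). For compound 4 the estimated half-life is 1.8 h, with a likely range from 0.9 h to 3.6 h.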

Compound 4, half-life: > 4.16 h
Compound 4 gave a limit, no number; the forecaster's own chance of this, stated with the estimate: 5%; middle value at least 2.3-fold (0.36 log units) away from the limit.
By their numbers in this assay, from the lowest: compounds 3, 2 and 1 (each within the scatter of the next, the first and the last beyond it). At a limit, above all of these: compound 4.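

At this position, on an aromatic carbon para to a large group, the group attached can shift the half-life beyond the usual scatter: methylcarbamoyl in place of cyclopropylsulfamoyl gives an at least 2.1-fold higher number from compound 2 to compound 4 (0.34 log units; beyond the scatter) in this assay. The earlier compounds shown here could not show this, as no two of them differed in one place and none of their numbers could be tied to a single change. Compound 4 stands at a limit and not at a number, so the step marks only a minimum and its full size stays unknown: the limit of > 4.16 h in this assay, at which 1 of the 4 values shown sits.

A single pair also leaves open which part of the change matters, since the sulfur, the three-membered ring and the heavy atom count all differ between the two groups, and the data do not separate them. Whether the same trend holds for a carboxylic acid, a simple unsubstituted carboxamide or an amide with a longer chain such as ethyl or propyl on its nitrogen remains an open question at this position on the shared core.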